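Swapping the Amide Group on Compound 2

This account rests on a few compounds, and the source may have more. Where it says the series, first, only, none or still open, it means among the compounds named here.

Compound 1 `CCCNc1nc(NCc2ccc(C(=O)NCc3ccc(F)cc3)cc2)c2cc(C)ccc2n1`: 4400 nM
Compound 2 `Cc1ccc2nc(N(C)C)nc(NCc3ccc(C(=O)Nc4ccc(Cl)nc4)cc3)c2c1`: 1300 nM

In a functional assay on HCT-116 cells (Homo sapiens) for inhibition, read by luminescence and resazurin assay, with a stated time of 3 days (a higher number here means a weaker inhibitor, a lower number a stronger inhibitor), compound 2, at 1300 nM, has the lower of the two numbers, and its gap to compound 1 lies beyond the usual scatter. Compound 3 `Cc1ccc2nc(N(C)C)nc(NCc3ccc(C(=O)NCc4ccc(F)cc4)cc3)c2c1` has not yet been measured. It differs from compound 2 in one place: 4-fluorobenzyl in place of 6-chloropyridin-3-yl on an amide-type nitrogen, with 4-fluorobenzyl in place of 6-chloropyridin-3-yl on an amide-type nitrogen. Compound 1 also carries 4-fluorobenzyl there and gives 4400 nM, although the rest of it is not identical, so weaker inhibition is expected. The expected change is a modest one, a 2.2-fold higher number from compound 2 to compound 3 (0.33 log units; beyond the scatter). For compound 3 the estimated value is 2800 nM, within a range of 900 nM to 8000 nM.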

Compound 3, half-maximal inhibitory concentration: 900 nM
Estimate against measurement, compound 3: 3.1-fold (0.49 log units) above; the measured number falls inside the stated range.
By their numbers in this assay, from the lowest: compounds 3 and 2 (each within the scatter of the next); then compound 1.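

Within this assay the swap of 6-chloropyridin-3-yl for 4-fluorobenzyl on the amide-type nitrogen gives a 1.4-fold lower number from compound 2 to compound 3 (0.16 log units; within the scatter) and the two compounds cannot be told apart. With 4-fluorobenzyl held in place, dimethylamino in place of propylamino on an aromatic carbon gives a 4.9-fold lower number from compound 1 to compound 3 (0.69 log units; beyond the scatter) so in this set the larger step sits at that aromatic carbon, not on the amide-type nitrogen. Nothing measured here explains either step.

Still open, going by these compounds, is how a non-aromatic group such as cyclohexyl would behave on the amide-type nitrogen. Also open, on these data alone, is how a morpholine in place of dimethylamino would behave on the aromatic carbon.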